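This account rests on a few compounds, and the source may have more. Where it says the series, first, only, none or still open, it means among the compounds named here.

Compound 1 `O=C1O/C(=C\Cn2cc(-c3cc(F)cc(F)c3)nn2)C(OCc2ccccc2)=C1OCc1ccccc1` was tested in a functional assay on HeLa cells (Homo sapiens) for antiproliferative activity, read by MTT assay, with a stated time of 72 h (a higher number here means a weaker inhibitor, a lower number a stronger inhibitor), where compound 1 gives 17700 nM. Among the measured compounds shown here, the only other measured compound, compound 2 `O=C1O[C@H]([C@@H](O)Cn2cc(CNS(=O)(=O)c3ccc(Cl)cc3F)nn2)C(OCc2ccccc2)=C1OCc1ccccc1`, shares the same core but carries a different chain on it; in this assay compound 2 gives 20700 nM. These two numbers lie within the usual scatter of each other, so neither compound can be called the stronger or the weaker inhibitor on this evidence. Compound 3 `O=C1O/C(=C\Cn2cc(-c3cccc(O)c3)nn2)C(OCc2ccccc2)=C1OCc1ccccc1` has not yet been measured. It differs from compound 1 in one place: 3-hydroxyphenyl in place of 3,5-difluorophenyl on an aromatic carbon. For the measured compounds named here, no measured pair of compounds shows what such a swap does here, so only a small step is expected, in either direction or none beyond the scatter, a 1.2-fold lower number from compound 1 to compound 3 (0.07 log units; within the scatter). Compound 3 is therefore estimated to give 15000 nM in this assay, with a range from 5000 nM to 45000 nM.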

Compound 3, half-maximal inhibitory concentration: 74800 nM
The estimate for compound 3 lay 5.0-fold (0.70 log units) below the measured number, outside the stated range (above it).
By their numbers in this assay, from the lowest: compounds 1 and 2 (each within the scatter of the next); then compound 3.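

Among the compounds shown here, compound 1 and compound 3 form the first measured pair that differs in one place, and they show that the group on this aromatic carbon of the five-membered ring is not a silent position. In this assay, 3-hydroxyphenyl in place of 3,5-difluorophenyl gives a 4.2-fold higher number from compound 1 to compound 3 (0.63 log units; beyond the scatter) and so a weaker inhibitor, a step beyond the usual scatter. The swap removes two fluorine atoms and adds a hydroxyl group in a single move, and no measurement here accounts for the loss.

Going by these compounds, it remains open whether losing the fluorine atoms or gaining the hydroxyl group matters more. A plain phenyl ring, or a phenyl ring carrying a single fluorine, a methoxy group or an amine, could help separate the two.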